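Nitrophenyl for methylphenyl on the amide of compound 3

The source may report more compounds than this note shows. Statements on the series, on what has been measured and on what is new or still open speak of the compounds shown alone.

Of the compounds shown here, three sharing one core have been measured in a functional assay on HL-60 cells (Homo sapiens) for antiproliferative activity, with a stated time of 24 h; a higher number here means a weaker inhibitor, a lower number a stronger inhibitor. Compound 1 `NC(=O)c1c(NC(=O)c2ccccc2)sc2c1CCN(C(=S)Nc1ccccc1Cl)C2` gives 13800 nM. Compound 2 `NC(=O)c1c(NC(=O)c2ccccc2Br)sc2c1CCN(C(=S)Nc1ccccc1Cl)C2` gives 14600 nM. Compound 3 `Cc1ccccc1C(=O)Nc1sc2c(c1C(N)=O)CCN(C(=S)Nc1ccccc1Cl)C2` gives 20900 nM. Compound 3 holds the highest of the three numbers, but its separation from the other two is small: a 1.5-fold higher number from compound 1 to compound 3 (0.18 log units; within the scatter) and a 1.4-fold higher number from compound 2 to compound 3 (0.16 log units; within the scatter), both of which are within the scatter of repeated measurements.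

Compound 4 `NC(=O)c1c(NC(=O)c2cccc([N+](=O)[O-])c2)sc2c1CCN(C(=S)Nc1ccccc1Cl)C2` is not yet measured. It differs from compound 3 in one place: 3-nitrophenyl in place of 2-methylphenyl on a carbonyl carbon. The measured steps that bear on this are the three changes on the same phenyl ring attached to the carbonyl carbon: a 1.1-fold higher number from compound 1 to compound 2 (0.02 log units; within the scatter), a 1.5-fold higher number from compound 1 to compound 3 (0.18 log units; within the scatter) and a 1.4-fold higher number from compound 2 to compound 3 (0.16 log units; within the scatter). None of them moves this assay beyond its scatter, so exchanging one small substituent on that ring for another has so far left the number where it was. Going by the values given here, compound 4 carries a larger change, a nitro group entering and a methyl leaving, and the data give no measured step of that kind. The expectation is therefore no step beyond the scatter: a 1.3-fold lower number from compound 3 to compound 4 (0.12 log units; within the scatter). Compound 4 is estimated at 16000 nM, with a range from 7000 nM to 40000 nM.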

Compound 4, half-maximal inhibitory concentration: 7040 nM
For compound 4 the middle estimate is 2.3-fold (0.36 log units) above the measured one, and the stated range covers the measured number.
By their numbers in this assay, from the lowest: compounds 4, 1, 2 and 3 (each within the scatter of the next, the first and the last beyond it).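

In this assay, the exchanges involving 3-nitrophenyl on the carbonyl carbon are the only ones on this ring to move the number beyond the scatter, though only modestly: replacing 2-methylphenyl gives (a 3.0-fold lower number from compound 3 to compound 4 (0.47 log units; beyond the scatter)), and replacing 2-bromophenyl gives (a 2.1-fold lower number from compound 2 to compound 4 (0.32 log units; beyond the scatter)). Measured against the plain phenyl ring, the same nitro group does not clear the scatter (a 2.0-fold lower number from compound 1 to compound 4 (0.29 log units; within the scatter)), so compound 4 separates from the two compounds with a substituent in the 2-position but not from compound 1. This position therefore accepts a nitro-bearing ring without any loss in this assay, and the only gains beyond the scatter are those measured against compound 2 and compound 3. Nothing among the available data accounts for the shift.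

Both steps that clear the scatter change the group and its place on the ring at once, so the compounds shown cannot separate the contribution of the nitro group from that of its location. As far as these compounds go, it also remains open whether an amine or a carboxylic acid on this phenyl ring would give a number like that of compound 4 or compound 1.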